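Replacing the imidazolylmethyl arm with a phenylpropyl chain

The source may hold more compounds than are shown below. What is called first, only, known or untested is meant among the compounds shown, and "the series" means these compounds.

Compound 2 `c1c[nH]c(CN2CCN(CCCc3c[nH]c4ccc(-n5cnnc5)cc34)CC2)n1` gives 2 nM in a functional assay on CHO cells for activation of 5-hydroxytryptamine receptor 1D (Homo sapiens), read by GTPgammaS binding (on this read-out higher numbers stand for an effect only at larger amounts of compound and lower numbers for an effect already at smaller amounts), the highest of the three numbers seen. Compound 1 `c1cc(CN2CCN(CCCc3c[nH]c4ccc(-n5cnnc5)cc34)CC2)ccn1` gives 1 nM, and the step of a 2.0-fold higher number from compound 1 to compound 2 (0.30 log units; within the scatter) stays within the scatter. Compound 3 `CN(C)C(=O)C(c1ccccc1)N1CCN(CCCc2c[nH]c3ccc(-n4cnnc4)cc23)CC1` gives 0.8 nM, a difference from compound 2 that lies beyond the scatter. Compound 4 `c1ccc(CCCN2CCN(CCCc3c[nH]c4ccc(-n5cnnc5)cc34)CC2)cc1` carries phenethyl in place of 1H-imidazol-2-yl on a saturated chain carbon bound to an amine nitrogen in a ring. Going by the values given here, only the step from compound 1 to compound 2 bears on a swap of the aromatic group at this place, and it was within the scatter; compound 3 shows that a quite different group here also gives a close number. For compound 4 the expected step of a 1.3-fold lower number from compound 2 to compound 4 (0.12 log units; within the scatter) is therefore small, no clear direction. Compound 4 is estimated at 1.5 nM, between 0.5 nM and 5 nM.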

Compound 4, half-maximal effective concentration: 4 nM
Beside the measured number, compound 4's estimate is 2.7-fold (0.43 log units) below it; low and high end bracket the measured number.
By their numbers in this assay, from the lowest: compounds 3, 1, 2 and 4 (each within the scatter of the next, the first and the last beyond it).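

Going from (1H-imidazol-2-yl)methyl to 3-phenylpropyl removes the hydrogen-bond donor and acceptor at this place, yet this assay shows only a 2.0-fold higher number from compound 2 to compound 4 (0.30 log units; within the scatter), so a low number here does not depend on them. Against the pyridin-4-yl group, the same arm gives a 4.0-fold higher number from compound 1 to compound 4 (0.60 log units; beyond the scatter), a modest step and the only one at this place that clears the scatter. No measurement here explains either step. Open, on these data alone, is how a benzyl group, with its shorter chain, would read, and whether an amine or a carboxylic acid at the end of the chain would keep the number this low.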